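Aryl group changes on a shared core

This account rests on a few compounds, and the source may have more. Where it says the series, first, only, none or still open, it means among the compounds named here.

In an ADME assay on J774 cells (Mus musculus) for antiproliferative activity, with a stated time of 72 h (a higher number here means that more compound is needed for the effect, a lower number that less compound is needed), compound 1 `CCCCc1cc2c(=O)c(-c3cccnc3)c(C)[nH]c2cc1OCCOc1ccccc1` gives 23000 nM, compound 2 `CCCCc1cc2c(=O)c(-c3ccc(OC(F)(F)F)cc3)c(C)[nH]c2cc1OCCOc1ccccc1` gives 20000 nM and compound 3 `CCCCc1cc2c(=O)c(-c3ccc(C(F)(F)F)cc3C)c(C)[nH]c2cc1OCCOc1ccccc1` gives 20000 nM. Compound 3 is thus level with compound 2 and within the scatter of compound 1. Compound 4 `CCCCc1cc2c(=O)c(-c3ccc(C)cc3C)c(C)[nH]c2cc1OCCOc1ccccc1` has methyl in place of trifluoromethyl on an aromatic carbon, meta to a methyl group and para to a large group: methyl in place of trifluoromethyl on an aromatic carbon. For the measured compounds named here, three measured steps bear on this change: a 1.2-fold lower number from compound 1 to compound 2 (0.06 log units; within the scatter), a 1.2-fold lower number from compound 1 to compound 3 (0.06 log units; within the scatter) and no change at the digits printed from compound 2 to compound 3 (within the scatter). None of them exchanges this group alone. Taking these three steps as a guide, the expected step in this assay is no change at the digits printed from compound 3 to compound 4 (within the scatter), with nothing beyond the scatter anticipated. Compound 4 is estimated at 20000 nM, with an expected range of 11000 nM to 35000 nM.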

Compound 4, half-maximal effective concentration: 22000 nM
Compound 4: middle estimate off by 1.1-fold (0.04 log units), on the low side; measured number inside the range.
By their numbers in this assay, from the lowest: compounds 2, 3, 4 and 1 (each within the scatter of the next).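

In this assay, the methyl for trifluoromethyl exchange is now read directly at this position, meta to a methyl group and para to a large group, giving a 1.1-fold higher number from compound 3 to compound 4 (0.04 log units; within the scatter) as the step. The 2,4-dimethylphenyl group also stays level with the other aryl groups, with a 1.1-fold higher number from compound 2 to compound 4 (0.04 log units; within the scatter) against 4-(trifluoromethoxy)phenyl and a 1.0-fold lower number from compound 1 to compound 4 (0.02 log units; within the scatter) against pyridin-3-yl. No accompanying measurement offers an explanation for this result. Going by these compounds, whether an amine, a carboxylic acid or a longer chain at this position would give a step beyond the scatter remains open.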